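From 4-methoxyphenyl to 3-ethoxyphenyl on a shared core

The source may report more compounds than this note shows. Statements on the series, on what has been measured and on what is new or still open speak of the compounds shown alone.

Compound 1 `COC(=O)N1N=C(c2cccc(OC)c2)CC1c1cc(OC)c(OC)c(OC)c1`: 2780 nM
Compound 2 `COC(=O)N1N=C(c2ccc(OC)cc2)CC1c1cc(OC)c(OC)c(OC)c1`: 5000 nM
Compound 3 `CCCOC(=O)N1N=C(c2ccc(OC)cc2)CC1c1cc(OC)c(OC)c(OC)c1`: 11700 nM

In a functional assay on A2780 cells (Homo sapiens) for antiproliferative activity, read by MTT assay, with a stated time of 48 h (on this read-out lower numbers stand for stronger inhibition of growth and higher numbers for weaker inhibition of growth), compound 2 has one close neighbour and one more distant one. The close gap is a 1.8-fold higher number from compound 1 to compound 2 (0.25 log units; within the scatter), and the wider gap is a 2.3-fold higher number from compound 2 to compound 3 (0.37 log units; beyond the scatter).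

Compound 4 `CCOc1cccc(C2=NN(C(=O)OC)C(c3cc(OC)c(OC)c(OC)c3)C2)c1` keeps the core of compound 2 and changes one group: 3-ethoxyphenyl in place of 4-methoxyphenyl on a carbon with a double bond to nitrogen. The nearest evidence is compound 1, which carries 3-methoxyphenyl and gives 2780 nM. The modest step to compound 3 comes from ethyl added at a different place, so it bears only loosely. The expected outcome is a 1.3-fold lower number from compound 2 to compound 4 (0.10 log units; within the scatter), so no change beyond the scatter is expected. For compound 4 the estimated value is 4000 nM, with an expected range of 1500 nM to 10000 nM.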

Compound 4, concentration for 50% growth inhibition: 760 nM
Compound 4: middle estimate off by 5.3-fold (0.72 log units), on the high side; measured number below the stated range.
By their numbers in this assay, from the lowest: compound 4; then compounds 1 and 2 (each within the scatter of the next); then compound 3.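

Adding one methyl to the 3-methoxyphenyl group, making it 3-ethoxyphenyl, gives in this assay a 3.7-fold lower number from compound 1 to compound 4 (0.56 log units; beyond the scatter) and so moves the number beyond the scatter, which the change from 3-methoxyphenyl to 4-methoxyphenyl did not do. Measured against the 4-methoxyphenyl group, the change gives a 6.6-fold lower number from compound 2 to compound 4 (0.82 log units; beyond the scatter). The group on this carbon with a double bond to nitrogen can therefore matter more than the change from 3-methoxyphenyl to 4-methoxyphenyl alone suggested. No measurement here explains this gain. On these data alone, whether a longer chain such as 3-propoxyphenyl lowers the number further remains open, as does whether 4-ethoxyphenyl matches 3-ethoxyphenyl.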